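The source may report more compounds than this note shows. Statements on the series, on what has been measured and on what is new or still open speak of the compounds shown alone.

Values in a functional assay on MCF7 cells (Homo sapiens) for antiproliferative activity, read by MTT assay, with a stated time of 6 days; on this read-out higher numbers stand for weaker inhibition and lower numbers for stronger inhibition
compound 1 `CC(=O)O[C@@H]1C=CC(=O)O[C@@H]1[C@@H](COC(=O)c1ccc(Cl)cc1)OC(C)=O` 2640 nM
compound 2 `O=C1C=C[C@@H](OC(=O)c2ccccc2)[C@@H]([C@@H](COC(=O)c2ccccc2)OC(=O)c2ccccc2)O1` 2360 nM
compound 3 `COc1cccc(C(=O)OC[C@@H](OC(=O)c2cccc(OC)c2)[C@H]2OC(=O)C=C[C@H]2OC(=O)c2cccc(OC)c2)c1` 30300 nM

Compound 1 (2640 nM) lies within the scatter of compound 2 (2360 nM), while compound 3 (30300 nM) stands above compound 1, beyond the scatter. Compound 4 `CC(=O)OC[C@@H](OC(C)=O)[C@H]1OC(=O)C=C[C@H]1OC(C)=O` puts methyl in place of 4-chlorophenyl on a carbonyl carbon. Among the compounds with values here, no measured pair isolates this change. In this assay a modest move towards a higher number is expected, possibly not beyond the scatter. Compound 1 and compound 2 (2360 nM) carry different esters yet sit close together, which argues against a large step. Compound 3 (30300 nM) keeps the upper range open. The estimated step of a 1.7-fold higher number from compound 1 to compound 4 (0.23 log units; within the scatter) is small. The expected value for compound 4 is 4500 nM, with an estimated range of 1300 nM to 18000 nM.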

Compound 4, half-maximal inhibitory concentration: 3870 nM
For compound 4 the middle estimate is 1.2-fold (0.07 log units) above the measured one; the measured number falls inside the stated range.
By their numbers in this assay, from the lowest: compounds 2, 1 and 4 (each within the scatter of the next); then compound 3.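

Methyl in place of 4-chlorophenyl on a carbonyl carbon gives a 1.5-fold higher number from compound 1 to compound 4 (0.17 log units; within the scatter) in this assay as the only one-place comparison in the series. At this position, the aromatic ring and its chlorine can therefore be replaced by methyl without a step beyond the scatter. No measurement shown offers an explanation for this result. On these data alone, it remains open whether a longer chain or an amine-bearing group on the same carbonyl carbon would also stay within the scatter. The contribution of the other ester positions cannot be read from these compounds.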